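Methyl for Methoxy on a Chlorinated Core

The compounds below may be only part of what the source reports. "The series", "measured", "known", "first", "only" and "open" are said of these compounds alone.

Compound 1 `CCN(CC)CN1C(=O)/C(=N/NC(=S)Nc2ccc(OC)cc2)c2ccccc21` and compound 2 `CCN(CC)CN1C(=O)/C(=N/NC(=S)Nc2ccc(C)cc2)c2ccccc21` share one core and differ by methyl in place of methoxy on an aromatic carbon. In an ADME assay on MDCK cells (Canis lupus familiaris) for cytotoxicity (a higher number here means that more compound is tolerated, a lower number that less compound is tolerated), compound 1 gives 4000 nM. In this assay compound 2 gives 800 nM. That change made a 5.0-fold lower number from compound 1 to compound 2 (0.70 log units; beyond the scatter). Compound 3 `CCN(CC)CN1C(=O)/C(=N/NC(=S)Nc2ccc(OC)cc2)c2cc(Cl)ccc21` differs from compound 1 by chloro in place of hydrogen on an aromatic carbon. In this assay compound 3 gives only a limit, >= 800 nM. The step that the limit leaves unreadable from compound 1 to compound 3 cannot be sized because compound 3 sits at the limit of >= 800 nM in this assay, at which 1 of the 3 values shown sits. Compound 4 `CCN(CC)CN1C(=O)/C(=N/NC(=S)Nc2ccc(C)cc2)c2cc(Cl)ccc21` differs from compound 3 by methyl in place of methoxy on an aromatic carbon, the same change, at the same place, as that from compound 1 to compound 2. Resting on a 5.0-fold lower number from compound 1 to compound 2 (0.70 log units; beyond the scatter), the step from compound 3 to compound 4 is expected to be a number no higher from compound 3 to compound 4 (the limit leaves the size open). Compound 4 is estimated in this assay at 800 nM, within 200 nM to 3200 nM.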

Compound 4, minimum cytotoxic concentration: 4000 nM
Compound 4: the middle estimate sits 5.0-fold (0.70 log units) below what was measured; the measured number lies above the stated range.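

On the chlorinated core the change from methoxy to methyl cannot be sized, and neither can any other step that involves compound 3, because compound 3 carries only a limit: the limit of >= 800 nM in this assay, at which 1 of the 4 values shown sits. What can be read is chloro in place of hydrogen with the 4-methylphenyl group kept, which gives a 5.0-fold higher number from compound 2 to compound 4 (0.70 log units; beyond the scatter). Going by these compounds alone, the result therefore neither confirms nor refutes that a 5.0-fold lower number from compound 1 to compound 2 (0.70 log units; beyond the scatter) carries over to the chlorinated core, and it shows only that methyl on that core does not rule out a value as high as that of compound 1.

From the compounds shown here alone, whether chloro in place of hydrogen acts the same way with methoxy remains open. So does how an amine or a carboxylic acid in place of methoxy would read in this assay on either core.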